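Pyrazole nitrogen substituent in a kinase inhibitor series

The source may report more compounds than this note shows. Statements on the series, on what has been measured and on what is new or still open speak of the compounds shown alone.

Measured so far:
compound 1 `Cc1c(Nc2nc(N)c3c(C#N)c(N4CCC[C@H]4C)n(C)c3n2)cnn1C` — 310 nM
compound 2 `Cc1nn(C2COC2)cc1Nc1nc(N)c2c(C#N)c(N3CCC[C@H]3C)n(C)c2n1` — 240 nM

In an assay on HEK293 cells for inhibition of Leucine-rich repeat serine/threonine-protein kinase 2 (Homo sapiens), with a stated time of 48 h (on this read-out lower numbers stand for stronger inhibition and higher numbers for weaker inhibition), compound 1 stands highest of the two numbers, with compound 2 nearest to it. Going by the values given here, the one measured step, a 1.3-fold lower number from compound 1 to compound 2 (0.11 log units; within the scatter), lies within the scatter. Compound 3 `Cc1c(Nc2nc(N)c3c(C#N)c(N4CCC[C@H]4C)n(C)c3n2)cnn1[C@H]1CCOC1` differs from compound 1 by oxolan-3-yl in place of methyl on an aromatic nitrogen. The step from compound 1 to compound 2 is the only one that bears on this change, and it was small; a step of similar size, in no clear direction, is therefore expected. For compound 3 the estimate is 260 nM (range 120 nM to 600 nM), which would mean an expected step of a 1.2-fold lower number from compound 1 to compound 3 (0.08 log units; within the scatter).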

Compound 3, half-maximal inhibitory concentration: 140 nM
For compound 3 the middle estimate is 1.9-fold (0.27 log units) above the measured one; low and high end bracket the measured number.
By their numbers in this assay, from the lowest: compounds 3, 2 and 1 (each within the scatter of the next, the first and the last beyond it).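

In this assay, going by these compounds alone, oxolan-3-yl in place of methyl on the aromatic nitrogen gives a 2.2-fold lower number from compound 1 to compound 3 (0.35 log units; beyond the scatter) and is the first step that lies beyond the scatter. This nitrogen therefore tolerates a larger group bearing a five-membered non-aromatic ring, with a modest gain on this read-out. No evidence at hand accounts for this step. Going by these compounds, the opposite configuration of the oxolan-3-yl stereocentre remains open. So does the role of the ring oxygen, which a cyclopentyl group or an amine such as piperidin-4-yl on this nitrogen would help to test.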